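Swapping isopropyl for (ethoxycarbonyl)methoxy on an aromatic nitrogen

The source may report more compounds than this note shows. Statements on the series, on what has been measured and on what is new or still open speak of the compounds shown alone.

In a functional assay on a cell-free system (plasma, Oryctolagus cuniculus) for inhibition, with stated times of 5 min, 1 min and 6 min (on this read-out lower numbers stand for stronger inhibition and higher numbers for weaker inhibition), compound 1 (`CCOC(=O)c1c(C)nc(-c2ccc(C#N)cc2)n1OC`) gives 13400 nM and compound 2 (`CCOC(=O)c1c(C)nc(-c2cccc(C#N)c2)n1C(C)C`) gives 9260 nM as its number, so the two stand level within the usual scatter of repeated measurements. Compound 3 (`CCOC(=O)COn1c(-c2cccc(C#N)c2)nc(C)c1C(=O)OCC`) is still unmeasured. Compared with compound 2, it carries (ethoxycarbonyl)methoxy in place of isopropyl on an aromatic nitrogen while the rest stays the same. Among the compounds with values here, no measured pair differs in just one place, so the data offer only indirect guidance. Compound 1 at 13400 nM and compound 2 at 9260 nM have different groups on that nitrogen, although they also differ elsewhere, and their values still agree within the scatter. The expected change is therefore small, with a 1.2-fold higher number from compound 2 to compound 3 (0.07 log units; within the scatter) estimated to stay within the scatter. For compound 3 the estimated value is 11000 nM with an expected range from 4000 nM to 30000 nM in this measurement.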

Compound 3, half-maximal inhibitory concentration: 6800 nM
Compound 3: middle estimate off by 1.6-fold (0.21 log units), on the high side; the measured number falls inside the stated range.
By their numbers in this assay, from the lowest: compounds 3, 2 and 1 (each within the scatter of the next).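

Within the data shown here, this is the first comparison in which only the group on the aromatic nitrogen changes, so the effect of that position can be read directly rather than inferred from compounds that also differ elsewhere. In this assay, replacing isopropyl with (ethoxycarbonyl)methoxy gives a 1.4-fold lower number from compound 2 to compound 3 (0.13 log units; within the scatter), so a group with more heavy atoms and with hydrogen-bond acceptors, which isopropyl lacks, leaves the number within the usual scatter. No supporting measurement explains why the two groups read alike.

A single swap cannot show whether any group at this position can move the number beyond the scatter. A carboxylic acid in place of the ethyl ester of the side chain, or an amine on a longer chain, would probe that question further.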